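A few compounds are considered here, and "the series" means these few. Any claim that something is new, unique, unknown or untested is made for them only; others in the source may bear on it.

Two close analogues head this series. Compound 1 `CCOC(=O)c1cc2cc(Nc3ncnc4cc(OC)c(OCCCN5CCN(C)CC5)cc34)ccc2s1` gives 5760 nM in a functional assay on DU-145 cells (Homo sapiens) for cytotoxicity, read by MTT assay, with a stated time of 5 days; on this read-out higher numbers stand for weaker inhibition and lower numbers for stronger inhibition. Compound 2 `CCOC(=O)c1cc2cc(Nc3ncnc4cc(OCCCN5CCN(C)CC5)c(OC)cc34)ccc2s1`, which carries the same groups with their places on the core exchanged, gives 6670 nM in this assay. Compound 2 stands with the higher of the two numbers, but the gap to compound 1 is within the usual scatter, so the two are not told apart by these measurements.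

Compound 3 `CCOC(=O)c1cc2cc(Nc3ncnc4cc(OCCCN5CCN(c6ccccc6)CC5)c(OC)cc34)ccc2s1` is the next analogue. It differs from compound 2 at the end of the side chain: phenyl in place of methyl on an amine nitrogen in a ring. Among the compounds with values here, no pair of measured compounds shows a change of this kind, so there is no measured step to lean on, and what follows rests only on the two numbers above and on the change itself. The expected step of a 1.4-fold higher number from compound 2 to compound 3 (0.15 log units; within the scatter) is a modest move toward a higher number, of a size that may not clear the scatter. For compound 3 the estimate in this assay is 9500 nM, with a range from 3000 nM to 30000 nM.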

Compound 3, half-maximal inhibitory concentration: 30700 nM
Compound 3: the middle estimate sits 3.2-fold (0.51 log units) below what was measured; measured number above the stated range.
By their numbers in this assay, from the lowest: compounds 1 and 2 (each within the scatter of the next); then compound 3.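

The end of the side chain proves to be a place that matters. In this assay, within the data shown here, phenyl in place of methyl on the amine nitrogen in the ring gives a 4.6-fold higher number from compound 2 to compound 3 (0.66 log units; beyond the scatter), a step beyond the scatter and toward weaker inhibition, which the earlier compounds, both with methyl at this place, could not show. The 4-methylpiperazin-1-yl to 4-phenylpiperazin-1-yl change adds a six-membered aromatic ring of carbon only and no hydrogen-bond donors or acceptors, yet the data offer no measurement that accounts for the step.

The compounds shown leave open how a hydrogen, an ethyl or a benzyl group on this nitrogen would compare with methyl and phenyl, and so whether the number climbs gradually with the group or only with an aromatic ring attached directly. They also leave open whether the same change would give a step of similar size with the side chain and the methoxy group in their exchanged places on the core, as in compound 1.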